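Urea versus amide at the anilide carbonyl: compound 4

A few compounds are considered here, and "the series" means these few. Any claim that something is new, unique, unknown or untested is made for them only; others in the source may bear on it.

Measured so far in a functional assay on 786-0 cells (Homo sapiens) for inhibition, read by sulforhodamine B assay, with a stated time of 48 h; a lower number here means a stronger inhibitor of growth, a higher number a weaker inhibitor of growth:
compound 1 `COc1cc(-c2nn(-c3cccc(NC(=O)Nc4cc(C(F)(F)F)cc(C(F)(F)F)c4)c3)cc2-c2ccncc2)ccc1Cl` — 950 nM
compound 2 `COc1cc(-c2nn(-c3cccc(NC(=O)c4cccc(C(F)(F)F)c4)c3)cc2-c2ccncc2)ccc1Cl` — 2450 nM
compound 3 `O=C(Nc1cccc(-n2cc(-c3ccncc3)c(-c3ccc(Cl)c(O)c3)n2)c1)Nc1cc(C(F)(F)F)cc(C(F)(F)F)c1` — 1170 nM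

Compound 2 stands highest of the three numbers in this assay. Its nearest neighbour is compound 3, and the gap is beyond the scatter; the gap to compound 1 is larger still. Among the measured compounds shown here, the one single-place step measured so far, a 1.2-fold higher number from compound 1 to compound 3 (0.09 log units; within the scatter), concerns the methoxy group on the shared core and is within the scatter, so it does not bear on the carbonyl end of the molecule.

Compound 4 `COc1cc(-c2nn(-c3cccc(NC(=O)Nc4ccc(Cl)c(C(F)(F)F)c4)c3)cc2-c2ccncc2)ccc1Cl` is the amide compound 2 turned into a urea: (4-chloro-3-(trifluoromethyl)phenyl)amino in place of 3-(trifluoromethyl)phenyl on a carbonyl carbon. For the measured compounds named here, no measured pair isolates this change. What the numbers show is that both ureas, compound 1 and compound 3, give lower numbers than the amide compound 2; compound 1 and compound 2 also differ in the substitution of the terminal aryl ring, so the comparison is not clean.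

On that basis compound 4 is expected to move toward the urea compounds, a step of roughly a 2.2-fold lower number from compound 2 to compound 4 (0.35 log units; beyond the scatter), though with some uncertainty since the terminal aryl pattern in compound 4 is new to the series. Compound 4 is therefore estimated at 1100 nM, within 500 nM to 2500 nM.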

Compound 4, concentration for 50% growth inhibition: 1610 nM
Estimate against measurement, compound 4: 1.5-fold (0.17 log units) below, within the range that was stated.
By their numbers in this assay, from the lowest: compounds 1, 3, 4 and 2 (each within the scatter of the next, the first and the last beyond it).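

In this assay, among the compounds shown here, the first single-place step at the carbonyl end, (4-chloro-3-(trifluoromethyl)phenyl)amino in place of 3-(trifluoromethyl)phenyl on a carbonyl carbon, comes to a 1.5-fold lower number from compound 2 to compound 4 (0.18 log units; within the scatter). This position therefore accepts the swap from the amide of compound 2 to the urea of compound 4 with no change that can be told from the usual scatter, and this pair gives no support for reading the urea as better than the amide here. No measurement at hand bears on why the number stays within the scatter across this change.

The change replaces the link to the terminal ring and adds chlorine in one step, so the compounds shown do not separate the contribution of the amino link from that of the chlorine; a urea carrying 3-(trifluoromethyl)phenyl, or an amide carrying 4-chloro-3-(trifluoromethyl)phenyl, would be needed to do so. From the compounds shown here alone, how a carboxylic acid or a simple alkyl amine would read on this carbonyl carbon, in place of the terminal aryl group, also stays open.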